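The source may report more compounds than this note shows. Statements on the series, on what has been measured and on what is new or still open speak of the compounds shown alone.

Compound 1 (`CCN1CCN(Cc2ccc(NC(=O)c3ccc(C)c(C#Cc4ccc(NC(C)=O)nc4)c3)cc2C(F)(F)F)CC1`): 2050 nM
Compound 2 (`CCN1CCN(Cc2ccc(NC(=O)c3ccc(C)c(C#Cc4cnc(N)cn4)c3)cc2C(F)(F)F)CC1`): 860 nM

For the measured compounds named here, in a functional assay on BaF3 cells (Mus musculus) for antiproliferative activity (a higher number here means that more compound is needed for the effect, a lower number that less compound is needed), compound 2 gives 860 nM, the lower of the two numbers so far, and the nearest number is that of compound 1 at 2050 nM. Compound 3 (`CCN1CCN(Cc2ccc(NC(=O)c3ccc(C)c(C#Cc4cnc5[nH]cnc5c4)c3)cc2C(F)(F)F)CC1`) keeps the core of compound 2 and differs only in the group on the triple-bonded carbon: a group of 9 heavy atoms (6 carbon, 3 nitrogen; one five-membered aromatic ring with 2 hetero atoms, one six-membered aromatic ring with 1 hetero atom) in place of a group of 7 heavy atoms (4 carbon, 3 nitrogen; one six-membered aromatic ring with 2 hetero atoms), on a triple-bonded carbon. Going by the values given here, one measured step bears on this, a 2.4-fold lower number from compound 1 to compound 2 (0.38 log units; beyond the scatter), a modest step that also exchanged the group at that place. One step cannot settle a direction for the entering group, so a step of similar modest size towards a lower number in this assay is expected only tentatively, and a step the other way remains possible. The expected change is a 1.9-fold lower number from compound 2 to compound 3 (0.28 log units; within the scatter). For compound 3 the estimated value is 450 nM, with an expected range from 110 nM to 1900 nM.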

Compound 3, half-maximal effective concentration: 60 nM
Compound 3: the middle estimate sits 7.5-fold (0.88 log units) above what was measured; measured number below the stated range.
By their numbers in this assay, from the lowest: compound 3; then compound 2; then compound 1.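

In this assay, the group on the triple-bonded carbon can move the number much further than the earlier exchange showed: compound 3 brings a 14-fold lower number from compound 2 to compound 3 (1.16 log units; beyond the scatter), a large step, and a 34-fold lower number from compound 1 to compound 3 (1.53 log units; beyond the scatter), also large. Among these three compounds, the group with one five-membered and one six-membered aromatic ring stands apart from the two groups with a single six-membered aromatic ring, whose own step was only modest. The 5-aminopyrazin-2-yl group and the group entering in compound 3 have the same count of hydrogen-bond donors, so that count does not track this step.

As far as these compounds go, it remains open which part of the entering group carries the step, and whether a methyl group or a fluorine placed on it would keep the low number. Nothing measured here offers an explanation for the size of the step.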